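Aryl ethers in place of cyclohexyl ether in the series

A few compounds are considered here, and "the series" means these few. Any claim that something is new, unique, unknown or untested is made for them only; others in the source may bear on it.

Measured so far:
compound 1 `Cc1nn(Cc2cccc(C(=O)Nc3ccccc3)c2)c(C)c1NC(=O)c1ccc(COc2ccccc2)cc1`: 6400 nM
compound 2 `CNC(=O)c1cccc(Cn2nc(C)c(NC(=O)c3ccc(COC4CCCCC4)cc3)c2C)c1`: 14000 nM
compound 3 `CNC(=O)c1cccc(Cn2nc(C)c(NC(=O)c3ccc(COc4cccc(C)c4)cc3)c2C)c1`: 6200 nM

All three numbers come from a functional assay on MIA PaCa-2 cells (Homo sapiens) for antiproliferative activity, read by MTT assay, with a stated time of 72 h; on this read-out lower numbers stand for an effect already at smaller amounts and higher numbers for an effect only at larger amounts of compound. Compound 2 stands highest of the three; its nearest neighbour is compound 1, and compound 3 lies furthest from it, both steps beyond the scatter. Compound 4 `CNC(=O)c1cccc(Cn2nc(C)c(NC(=O)c3ccc(COc4ccc(C(F)(F)F)cc4)cc3)c2C)c1` is not yet measured. It differs from compound 2 in one place: 4-(trifluoromethyl)phenyl in place of cyclohexyl on an oxygen on a saturated carbon.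

For the measured compounds named here, the one measured step that bears on this change is a 2.3-fold lower number from compound 2 to compound 3 (0.35 log units; beyond the scatter), where an aromatic ring replaces the cyclohexyl on the same oxygen. Compound 4 makes the same kind of exchange, with 4-(trifluoromethyl)phenyl rather than 3-methylphenyl entering. Nothing in the data separates the two aryl groups from each other, so the expectation is a step of about the size seen from compound 2 to compound 3, in the direction of a lower number, estimated as a 2.2-fold lower number from compound 2 to compound 4 (0.33 log units; beyond the scatter). Compound 4 is therefore estimated at 6500 nM, within a range from 3000 nM to 14000 nM.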

Compound 4, half-maximal effective concentration: 800 nM
Compound 4: middle estimate off by 8.1-fold (0.91 log units), on the high side; measured number outside the range, below it.
By their numbers in this assay, from the lowest: compound 4; then compounds 3 and 1 (each within the scatter of the next); then compound 2.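

In this assay, the kind of aromatic ring entering on this oxygen matters far more than the first aryl exchange suggested: an 18-fold lower number from compound 2 to compound 4 (1.24 log units; beyond the scatter), against a 2.3-fold lower number from compound 2 to compound 3 (0.35 log units; beyond the scatter). Exchanging one aryl group for another still gives a 7.8-fold lower number from compound 3 to compound 4 (0.89 log units; beyond the scatter), so replacing cyclohexyl with an aromatic ring does not by itself set the size of the step, and the group carried on that ring makes a clear difference. No available data explain the step seen with 4-(trifluoromethyl)phenyl.

Compound 3 and compound 4 differ in both the group on the aromatic ring and its place on that ring, so the contribution of each remains unresolved. Going by these compounds, it also remains open whether a chlorine, a methoxy group or an amine on the ring would give a step of similar size.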